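Chain length on the anilide ring: compound 4

This account rests on a few compounds, and the source may have more. Where it says the series, first, only, none or still open, it means among the compounds named here.

Compound 1 `CCCCOc1ccc(NS(=O)(=O)c2ccc(N3CCNC3=O)cc2)cc1`, compound 2 `COc1cccc(NS(=O)(=O)c2ccc(N3CCNC3=O)cc2)c1` and compound 3 `Cc1ccc(C)c(NS(=O)(=O)c2ccc(N3CCNC3=O)cc2)c1` share one core and differ only in the aryl group on the sulfonamide nitrogen. In a functional assay on MCF7 cells (Homo sapiens) for antiproliferative activity, read by sulforhodamine B assay, with a stated time of 48 h (on this read-out higher numbers stand for weaker inhibition and lower numbers for stronger inhibition), compound 1 gives 870 nM, compound 2 gives 120 nM and compound 3 gives 48 nM. Compound 1 therefore stands highest of the three numbers, beyond the scatter from both others. Among the measured compounds shown here, the one recorded single-point step, a 2.5-fold lower number from compound 2 to compound 3 (0.40 log units; beyond the scatter), swaps the whole aryl group and says nothing about a chain para to a large group. Compound 4 `CCCCCCCc1ccc(NS(=O)(=O)c2ccc(N3CCNC3=O)cc2)cc1` differs from compound 1 by heptyl in place of butoxy on an aromatic carbon. For the measured compounds named here, no measured step covers this exchange, so no direction beyond the scatter is supported. Compound 4 is expected at 1200 nM, range 400 nM to 4000 nM, meaning an estimated 1.4-fold higher number from compound 1 to compound 4 (0.14 log units; within the scatter).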

Compound 4, half-maximal inhibitory concentration: > 1000 nM
Compound 4 gave a limit, no number (the forecaster's own chance of this, stated with the estimate: 10%); the middle value is on the limit's open side.
By their numbers in this assay, from the lowest: compound 3; then compound 2; then compound 1. At a limit, above all of these: compound 4.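

In this assay compound 4 gives > 1000 nM, a limit of the assay and not a number. Heptyl in place of butoxy, para to a large group, gives an at least 1.1-fold higher number from compound 1 to compound 4 (0.06 log units; that floor lies within the scatter), so the exchange brings no lower number and its true size stays unfixed. Compound 4 alone in the series reads as a limit: the limit of > 1000 nM in this assay, at which 1 of the 4 values shown sits.

Left open is how a shorter alkoxy chain, a longer chain or an amine on this aromatic carbon would read. Compound 1 and compound 4 differ in both chain length and the ether oxygen, so this one step cannot separate the two.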